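The source may hold more compounds than are shown below. What is called first, only, known or untested is meant among the compounds shown, and "the series" means these compounds.

Compound 1 `COc1ccc(C(=O)N2CCC(=CC(=O)N[C@@H]3CCN(Cc4ccc5cc(F)ccc5c4)C3)CC2)cc1` is the starting point. In an in vitro ADME assay on microsomes from liver (Homo sapiens) for metabolic stability (a higher number here means faster removal of the compound, a lower number slower removal), compound 1 gives 252 mL/min/kg. Among the compounds with values here, only one other compound has been measured beside it: compound 2 `COc1cccc(O)c1C(=O)N1CCC(=CC(=O)N[C@@H]2CCN(Cc3ccc4cc(F)ccc4c3)C2)CC1`, which in this assay gives 192 mL/min/kg, so that the step of a 1.3-fold lower number from compound 1 to compound 2 (0.12 log units; within the scatter) lies within the scatter and compound 1 is not set apart from its only neighbour. Compound 3 `COc1ccc(C(=O)N2CCC(=CC(=O)N[C@@H]3CCN(Cc4ccc5cc(F)ccc5c4)C3)CC2)c(O)c1` has not yet been measured. It differs from compound 1 in one place: hydroxy in place of hydrogen on an aromatic carbon. Within the data shown here, the only measured step that bears on this change is the one from compound 1 to compound 2, where a hydroxy group also entered the aromatic ring on the carbonyl carbon, in the form of 2-hydroxy-6-methoxyphenyl in place of 4-methoxyphenyl, and that step stayed within the scatter. On this basis no step beyond the scatter is expected for compound 3, and the expected step is a 1.1-fold lower number from compound 1 to compound 3 (0.06 log units; within the scatter). Compound 3 is therefore estimated at 220 mL/min/kg in this assay, with a range from 130 mL/min/kg to 380 mL/min/kg.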

Compound 3, clearance: 232 mL/min/kg
Compound 3: middle estimate off by 1.1-fold (0.02 log units), on the low side; low and high end bracket the measured number.
By their numbers in this assay, from the lowest: compounds 2, 3 and 1 (each within the scatter of the next).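

In this assay, within the data shown here, hydroxy on the aromatic carbon ortho to a large group and meta to a methoxy group now stands as the only change, and a 1.1-fold lower number from compound 1 to compound 3 (0.04 log units; within the scatter) shows that this one change does not set the two compounds apart. The other new step, with 2-hydroxy-4-methoxyphenyl in place of 2-hydroxy-6-methoxyphenyl, reads a 1.2-fold higher number from compound 2 to compound 3 (0.08 log units; within the scatter) and adds that the two arrangements of hydroxy and methoxy on this ring are not told apart either. No measurement at hand gives a reason for these results.

On these data alone, all three compounds keep the shared core and differ only on the aromatic ring on the carbonyl, so it remains open whether a change elsewhere in the molecule would produce a step beyond the scatter. As far as these compounds go, it also remains open whether a carboxylic acid, an amine or a longer alkoxy chain in place of the methoxy group would do so.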